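The compounds below may be only part of what the source reports. "The series", "measured", "known", "first", "only" and "open" are said of these compounds alone.

Among the compounds with values here, compound 2 `N=C(N)c1ccc(O)c(CN2CC[C@H](NS(=O)(=O)c3cc4nc(Cl)ccc4s3)C2=O)c1` is the only member of this series with a number in an assay on isolated protein for binding affinity to vitamin K-dependent protein C (Homo sapiens) (a lower number here means a stronger inhibitor, a higher number a weaker inhibitor), where compound 2 gives 11000 nM. Compound 1 `N=C(N)c1cccc(CN2CC[C@H](NS(=O)(=O)c3cc4nc(Cl)ccc4s3)C2=O)c1` sits at a limit of this assay, > 18000 nM. Within the data shown here, the one measured step, an at least 1.6-fold lower number from compound 1 to compound 2 (0.21 log units; that floor lies within the scatter), bears only on the hydroxy group. Among the measured compounds shown here, compound 3 `N=C(N)c1ccc(O)c(CN2CC[C@H](NS(=O)(=O)c3cc4ccnc(Cl)c4s3)C2=O)c1` changes (a group of 10 heavy atoms (7 carbon, 1 nitrogen, 1 sulfur, 1 chlorine; one five-membered aromatic ring with 1 hetero atom, one six-membered aromatic ring with 1 hetero atom) in place of a group of 10 heavy atoms (7 carbon, 1 nitrogen, 1 sulfur, 1 chlorine; one five-membered aromatic ring with 1 hetero atom, one six-membered aromatic ring with 1 hetero atom), on a sulfonyl sulfur); no measured step touches that group, so no direction beyond the scatter is expected, and the step of no change at the digits printed from compound 2 to compound 3 (within the scatter) is estimated at zero. Compound 3 is therefore expected near 11000 nM, between 3500 nM and 35000 nM in this assay.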

Compound 3, inhibition constant: 5500 nM
Compound 3: middle estimate off by 2.0-fold (0.30 log units), on the high side, and the stated range covers the measured number.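

Within the data shown here, this is the first reading at the position on a sulfonyl sulfur. In this assay, exchanging one group of 10 heavy atoms for another made of the same atoms, joined differently, gives a 2.0-fold lower number from compound 2 to compound 3 (0.30 log units; within the scatter). This rearrangement therefore produces no change beyond the scatter, with the hydroxy group present in both compounds.

As far as these compounds go, whether a different group on the sulfonyl sulfur, such as a plain phenyl ring or an amine-bearing ring, would move the number beyond the scatter stays open. The full size of the hydroxy step also stays open, since compound 1 stands at a limit: the limit of > 18000 nM in this assay, at which 1 of the 3 values shown sits.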